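The source may hold more compounds than are shown below. What is called first, only, known or untested is meant among the compounds shown, and "the series" means these compounds.

Measured so far:
compound 1, `CC1CC(C)CN(c2nc(Nc3ccc(C#N)c(C(F)(F)F)c3)nc(Oc3ccnc4ccccc34)n2)C1`: 68000 nM
compound 2, `CCN1CCN(c2nc(Nc3ccc(C#N)c(C(F)(F)F)c3)nc(Oc3ccnc4ccccc34)n2)CC1`: > 100000 nM (a limit)

In a functional assay on DU-145 cells (Homo sapiens) for cytotoxicity, read by sulforhodamine B assay, with a stated time of 48 h (on this read-out higher numbers stand for weaker inhibition of growth and lower numbers for stronger inhibition of growth), compound 1 gives 68000 nM. Compound 2 reaches only (the limit of > 100000 nM in this assay, at which 1 of the 2 values shown sits), a limit rather than a number, so it stands at the weak end of the pair with nothing more exact known. Among the compounds with values here, the only measured step, an at least 1.4-fold higher number from compound 1 to compound 2 (0.16 log units; that floor lies within the scatter), is itself a floor within the scatter. Compound 3, `N#Cc1ccc(Nc2nc(Oc3ccnc4ccccc34)nc(N3CCN(c4ccccc4)CC3)n2)cc1C(F)(F)F`, differs from compound 2 by phenyl in place of ethyl on an amine nitrogen in a ring. Within the data shown here, no measured step bears on this change, so no shift beyond the scatter is expected. Compound 3 is estimated at 100000 nM, between 30000 nM and 300000 nM. That estimate means a number no higher from compound 2 to compound 3 (the limit leaves the size open).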

Compound 3, concentration for total growth inhibition: > 100000 nM
Compound 3 ended at the assay's limit; the forecaster's own chance of this, stated with the estimate: 60%; the middle value sits exactly at the limit.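

In this assay compound 3 gives > 100000 nM, a limit and not a number. With phenyl in place of ethyl on the ring amine nitrogen, the reading stays at the limit, so the step between these two limited values cannot be read. The step to the 4-phenylpiperazin-1-yl group, an at least 1.4-fold higher number from compound 1 to compound 3 (0.16 log units; that floor lies within the scatter), gives no change beyond the scatter, and the series now reads: the limit of > 100000 nM in this assay, at which 2 of the 3 values shown sit.

On these data alone, whether a benzyl group or a hydroxyethyl chain on that nitrogen would give a readable number stays open. So does the effect of any change at this nitrogen on growth inhibition.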